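Thiosemicarbazide series: positional isomer of the methylphenyl amide

A few compounds are considered here, and "the series" means these few. Any claim that something is new, unique, unknown or untested is made for them only; others in the source may bear on it.

Measured compounds:
- compound 1, `O=C(NC(=S)NNc1ncnc2ccccc12)c1ccccc1`, 8370 nM in a functional assay on GLC82 cells (Homo sapiens) for cytotoxicity, read by MTT assay, with a stated time of 72 h; a higher number here means a weaker inhibitor, a lower number a stronger inhibitor
- compound 2, `Cc1ccc(C(=O)NC(=S)NNc2ncnc3ccccc23)cc1`, 11200 nM in this assay

For the measured compounds named here, compound 2 carries the highest of the two numbers so far in this assay, but its only neighbour is compound 1, and the step of a 1.3-fold higher number from compound 1 to compound 2 (0.13 log units; within the scatter) lies within the scatter, so the two compounds cannot be told apart on these data.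

Compound 3, `Cc1ccccc1C(=O)NC(=S)NNc1ncnc2ccccc12`, has the same atoms as compound 2 joined differently: 2-methylphenyl in place of 4-methylphenyl on a carbonyl carbon. Going by the values given here, no measured pair changes the place of a group on this ring; the only step on record, a 1.3-fold higher number from compound 1 to compound 2 (0.13 log units; within the scatter), concerns adding the methyl and is within the scatter. With nothing to suggest that where the methyl sits matters more than whether it is present, the expectation for compound 3 in this assay is a step of a 1.1-fold lower number from compound 2 to compound 3 (0.05 log units; within the scatter), that is, none beyond the scatter, with a wide uncertainty. Compound 3 is therefore estimated at 10000 nM, in the range 4000 nM to 28000 nM.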

Compound 3, half-maximal inhibitory concentration: 13200 nM
Compound 3: the middle estimate sits 1.3-fold (0.12 log units) below what was measured; the range from low to high includes it.
By their numbers in this assay, from the lowest: compounds 1, 2 and 3 (each within the scatter of the next).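

Moving the methyl from 4-methylphenyl to 2-methylphenyl on a carbonyl carbon gives a 1.2-fold higher number from compound 2 to compound 3 (0.07 log units; within the scatter) in this assay. For the compounds shown here, this is the only step that changes the place of a group on this ring, and on these data the two isomers cannot be told apart. Read against the plain phenyl of compound 1, the 2-methylphenyl group gives a 1.6-fold higher number from compound 1 to compound 3 (0.20 log units; within the scatter), so neither methyl isomer can be separated from compound 1 and all three compounds remain one group in this assay; no other measurement on hand bears on this result.

The compounds shown carry only hydrogen or methyl on this ring, all on the same core, so the series does not yet show whether this ring can shift the number beyond the scatter at all. On these data alone, whether a chlorine, a methoxy, an amine, a carboxylic acid or a longer chain such as ethyl in place of the methyl would do so remains open, as does the effect of any change to the shared core.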